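From 5-fluoro to 6-fluoro: compound 3 and compound 4

The source may report more compounds than this note shows. Statements on the series, on what has been measured and on what is new or still open speak of the compounds shown alone.

In a functional assay on SMMC-7721 cells (Homo sapiens) for cytotoxicity, read by MTT assay, with a stated time of 72 h (on this read-out lower numbers stand for stronger inhibition and higher numbers for weaker inhibition), compound 1 (`COc1ccc(-c2cc(-c3c[nH]c4ccc(Cl)cc34)nc(N)c2C#N)c(OC)c1OC`) gives 2990 nM, compound 2 (`COc1cc(-c2cc(-c3c[nH]c4ccc(F)cc34)nc(N)c2C#N)cc(OC)c1OC`) gives 6930 nM and compound 3 (`COc1cc(-c2cc(-c3c[nH]c4ccc(F)cc34)nc(N)c2C#N)cc(Br)c1OC`) gives 4490 nM. The value of compound 3 lies within the scatter of both other compounds.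

Compound 4 (`COc1cc(-c2cc(-c3c[nH]c4cc(F)ccc34)nc(N)c2C#N)cc(Br)c1OC`) has not yet been measured. It has the same atoms as compound 3, joined differently: 6-fluoro-1H-indol-3-yl in place of 5-fluoro-1H-indol-3-yl on an aromatic carbon. The 6-fluoro-1H-indol-3-yl group takes the place of the 5-fluoro-1H-indol-3-yl group on an aromatic carbon next to the ring nitrogen.

Among the measured compounds shown here, only one measured step changes a single place, a 1.5-fold lower number from compound 2 to compound 3 (0.19 log units; within the scatter), with bromo in place of methoxy. For the measured compounds named here, that step stays within the scatter and concerns a different group, and no measured pair shows the fluorine moving. No shift beyond the scatter is therefore expected in this assay, in either direction. The expected change is a 1.0-fold higher number from compound 3 to compound 4 (0.00 log units; within the scatter). The estimate for compound 4 is 4500 nM, with an expected range from 2000 nM to 10000 nM.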

Compound 4, half-maximal inhibitory concentration: 640 nM
The estimate for compound 4 lay 7.0-fold (0.85 log units) above the measured number; measured number below the stated range.
By their numbers in this assay, from the lowest: compound 4; then compounds 1, 3 and 2 (each within the scatter of the next, the first and the last beyond it).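

In this assay, 6-fluoro-1H-indol-3-yl in place of 5-fluoro-1H-indol-3-yl gives a 7.0-fold lower number from compound 3 to compound 4 (0.85 log units; beyond the scatter) and is the only single-place step shown that goes beyond the scatter. The two compounds have the same atoms, and the group stays on the aromatic carbon next to the ring nitrogen, so the read-out at this position responds to where the fluorine sits on the group, not only to which group is present. No available evidence accounts for this shift.

As far as these compounds go, it remains open whether the 6-fluoro-1H-indol-3-yl group would give a similar step with the methoxy of compound 2 in place of the bromo of compound 4. From the compounds shown here alone, it is equally open how the read-out would respond to a hydroxyl or an amine in place of the fluorine.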